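Exchanging the Group on Sulfur in a Flat Series

A few compounds are considered here, and "the series" means these few. Any claim that something is new, unique, unknown or untested is made for them only; others in the source may bear on it.

In a functional assay on A549 cells (Homo sapiens) for inhibition, read by CCK-8 assay, with a stated time of 72 h, tested at 8 uM (on this read-out lower numbers stand for less inhibition of growth and higher numbers for more inhibition of growth at the one concentration tested), compound 3 `Nc1ccccc1NC(=O)/C=C/c1ccc(CSc2ccc(C(F)(F)F)cn2)cc1` gives 56.5% and sits within the scatter of the other two measured compounds: compound 1 `Nc1ccccc1NC(=O)/C=C/c1ccc(CSc2ccc(Cl)cc2)cc1` gives 59.6% and compound 2 `Nc1ccccc1NC(=O)/C=C/c1ccc(CSc2cccc(F)c2)cc1` gives 56.6% here. Compound 4 `Cc1ccc(SCc2ccc(/C=C/C(=O)Nc3ccccc3N)cc2)cc1` differs from compound 3 in one place: 4-methylphenyl in place of 5-(trifluoromethyl)pyridin-2-yl on a sulfur and so 4-methylphenyl replaces 5-(trifluoromethyl)pyridin-2-yl on a sulfur. Three measured exchanges on that sulfur bear on this: a number 3 percentage points lower from compound 1 to compound 2 (within the scatter) and a number 3.1 percentage points lower from compound 1 to compound 3 (within the scatter) and a number 0.1 percentage points lower from compound 2 to compound 3 (within the scatter) are all small. With all three inside the scatter, no step beyond it is expected in this assay here. The estimated step is a number 1.5 percentage points higher from compound 3 to compound 4 (within the scatter) and no more. For compound 4 the expected value is 58% with an estimated range from 47% to 69% in this test.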

Compound 4, percent growth inhibition at one concentration: 48.3%
Compound 4: the middle estimate sits 9.7 percentage points above what was measured; low and high end bracket the measured number.
By their numbers in this assay, from the lowest: compounds 4, 3, 2 and 1 (each within the scatter of the next, the first and the last beyond it).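

In this assay, within the data shown here, 4-methylphenyl gives the first exchange on the sulfur to pass the scatter, as a number 11.3 percentage points lower from compound 1 to compound 4 (beyond the scatter) is a modest step with methyl in place of chloro on an aromatic carbon. Among these compounds, the other two steps, a number 8.2 percentage points lower from compound 3 to compound 4 (within the scatter) and a number 8.3 percentage points lower from compound 2 to compound 4 (within the scatter), stay within the scatter, so the position is no longer wholly flat, yet only one pair shows this. Nothing measured here gives a reason for the step. Still open, from the compounds shown here alone, is what a 4-methoxyphenyl or a 4-aminophenyl group on the sulfur would give.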